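Trifluoromethyl for methyl in an antiproliferative series

The source may hold more compounds than are shown below. What is called first, only, known or untested is meant among the compounds shown, and "the series" means these compounds.

Compound 1 `COc1ccc(-c2[nH]c3cc(Cl)ccc3c2C=O)cc1` at 65 nM in a functional assay on MCF7 cells (Homo sapiens) for antiproliferative activity, with a stated time of 5 days; on this read-out lower numbers stand for stronger inhibition and higher numbers for weaker inhibition
Compound 2 `Cc1ccc(-c2[nH]c3ccc(C)cc3c2C=O)cc1` at 165 nM in this assay
Compound 3 `CCCCc1ccc2[nH]c(-c3ccc(C)cc3)c(C=O)c2c1` at 54 nM in this assay

Compound 3 sits at 54 nM in this assay and lies within the scatter of compound 1 at 65 nM while compound 2 stands apart with the higher number at 165 nM in this small set.

Compound 4 `CCCCc1ccc2[nH]c(-c3ccc(C(F)(F)F)cc3)c(C=O)c2c1` comes from compound 3 by a single change. That change is trifluoromethyl in place of methyl on an aromatic carbon and in words it is trifluoromethyl in place of methyl on an aromatic carbon.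

Among the measured compounds shown here, only one measured step links compounds that differ in one place. It is a 3.1-fold lower number from compound 2 to compound 3 (0.49 log units; beyond the scatter) and it concerns propyl in place of hydrogen on a saturated chain carbon bound to an aromatic carbon, which is a different change from the one at issue. For the measured compounds named here, no measured step replaces this methyl, so the data give no direct size for the swap. With so little to go on, no shift beyond the scatter is expected, with a slight lean towards a higher number. The expected step is a 1.5-fold higher number from compound 3 to compound 4 (0.17 log units; within the scatter) in this assay and it remains an estimate. Compound 4 is estimated at 80 nM with an expected range from 25 nM to 250 nM in this assay until it is measured.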

Compound 4, half-maximal inhibitory concentration: 66 nM
For compound 4 the middle estimate is 1.2-fold (0.08 log units) above the measured one; measured number inside the range.
By their numbers in this assay, from the lowest: compounds 3, 1 and 4 (each within the scatter of the next); then compound 2.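

In this assay, trifluoromethyl in place of methyl on an aromatic carbon gives a 1.2-fold higher number from compound 3 to compound 4 (0.09 log units; within the scatter), the only step among these compounds that reports on this position. On this six-membered aromatic ring of carbon only, para to a large group, the read-out therefore does not separate the one-heavy-atom methyl from the four-heavy-atom trifluoromethyl, although both groups carry no hydrogen-bond donors or acceptors and no net charge. Nothing available here speaks to why the two groups read alike at this position.

The compounds shown leave open whether this tolerance extends to groups of a different kind at the same place, such as an amine, a carboxylic acid or a longer chain, any of which would test it with a donor, an acceptor, a charge or more bulk than these two groups bring. They also leave open whether the same swap would read alike on the core of compound 2, where the other step shown, a 3.1-fold lower number from compound 2 to compound 3 (0.49 log units; beyond the scatter), lies beyond the scatter and the chain at the far end of the molecule is shorter.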